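Working notes: methoxy to hydroxy, compound 3 to compound 4

The source may report more compounds than this note shows. Statements on the series, on what has been measured and on what is new or still open speak of the compounds shown alone.

Three compounds share one core and differ only in the group on the aromatic ring. In an ADME assay on J774 cells (Mus musculus) for cytotoxicity, read by MTT assay, with a stated time of 48 h, tested at 150 ug/mL (on this read-out lower numbers stand for a stronger effect and higher numbers for a weaker effect at the one concentration tested), compound 1 `O=C(N/N=C/c1ccccc1Cl)c1cnccn1` gives 69%, compound 2 `O=C(N/N=C/c1ccccc1F)c1cnccn1` gives 81%, and compound 3 `COc1ccccc1/C=N/NC(=O)c1cnccn1` gives 97%. Compound 3 stands highest of the three, beyond the scatter against both: a number 16 percentage points higher from compound 2 to compound 3 (beyond the scatter) and a number 28 percentage points higher from compound 1 to compound 3 (beyond the scatter); the remaining step is a number 12 percentage points higher from compound 1 to compound 2 (beyond the scatter). Compound 4 `O=C(N/N=C/c1ccccc1O)c1cnccn1` differs from compound 3 by hydrogen in place of methyl on an oxygen on an aromatic ring. Going by the values given here, no measured step changes methoxy to hydroxy; the three steps only show that swapping the group at this place moves this assay modestly. A modest move is therefore expected, direction uncertain, leaning lower because compound 3 at 97% leaves little room above. Compound 4 is expected near 88%, within 70% to 100%. The expected step is a number 9 percentage points lower from compound 3 to compound 4 (within the scatter).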

Compound 4, a percentage reported as activity, at one concentration (the size of the read-out at that concentration, not a potency): 0%
Compound 4: middle estimate off by 88 percentage points, on the high side; measured number outside the range, below it.
By their numbers in this assay, from the lowest: compound 4; then compound 1; then compound 2; then compound 3.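

In this assay this place on the aromatic ring proves far more sensitive than the modest moves among chloro, fluoro and methoxy suggested: hydrogen in place of methyl on the oxygen gives a number 97 percentage points lower from compound 3 to compound 4 (beyond the scatter). Hydroxy also parts from both halogens, with a number 81 percentage points lower from compound 2 to compound 4 (beyond the scatter) and a number 69 percentage points lower from compound 1 to compound 4 (beyond the scatter), so compound 4 shows the strongest effect of the four, and an oxygen alone does not account for it, since compound 3 also carries one.

Nothing available explains the size of this step. Going by these compounds, whether an amine or a carboxylic acid at this place would behave like hydroxy remains open.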